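Removing the chloro from the urea aryl of compound 2

The source may hold more compounds than are shown below. What is called first, only, known or untested is meant among the compounds shown, and "the series" means these compounds.

In a functional assay on IGROV-1 cells (Homo sapiens) for inhibition, read by sulforhodamine B assay, with a stated time of 48 h, tested at 100 uM (on this read-out lower numbers stand for a stronger effect and higher numbers for a weaker effect at the one concentration tested), compound 1 `O=C(Nc1cccc(-n2cc(-c3ccncc3)c(-c3cc(O)cc(Cl)c3)n2)c1)Nc1ccc(Cl)c(C(F)(F)F)c1` gives -41% and compound 2 `COc1cc(Cl)cc(-c2nn(-c3cccc(NC(=O)Nc4ccc(Cl)c(C(F)(F)F)c4)c3)cc2-c2ccncc2)c1` gives -16%, the higher of the two numbers. Within the data shown here, the one measured step, a number 25 percentage points higher from compound 1 to compound 2 (beyond the scatter), changes a different part of the shared core and so does not bear on the change at hand. Compound 3 `COc1cc(Cl)cc(-c2nn(-c3cccc(NC(=O)Nc4cccc(C(F)(F)F)c4)c3)cc2-c2ccncc2)c1` differs from compound 2 by hydrogen in place of chloro on an aromatic carbon. Among the measured compounds shown here, with no measured step at that place, no direction can be read off; the step of a number 11 percentage points higher from compound 2 to compound 3 (beyond the scatter) is expected to stay within the scatter, though a step either way cannot be ruled out. Compound 3 is therefore estimated at -5%, between -35% and 25%.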

Compound 3, a percentage reported as activity, at one concentration (the size of the read-out at that concentration, not a potency): -12%
Beside the measured number, compound 3's estimate is 7 percentage points above it; the range from low to high includes it.
By their numbers in this assay, from the lowest: compound 1; then compounds 2 and 3 (each within the scatter of the next).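

In this assay, replacing the chloro of the 4-chloro-3-(trifluoromethyl)phenyl group with hydrogen gives a number 4 percentage points higher from compound 2 to compound 3 (within the scatter), so chloro and hydrogen cannot be told apart at this position, ortho to the trifluoromethyl group. Among these compounds, this is the first reading at this end of the molecule, and unlike the earlier step on the other aryl group, it stays within the scatter. No available evidence accounts for this result. Still open, on these data alone, is whether an amine or a carboxylic acid at this position would move the number, and whether the neighbouring trifluoromethyl group could be replaced by hydrogen.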